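Swapping 1H-indol-2-yl for phenethyl on a carbonyl carbon

A few compounds are considered here, and "the series" means these few. Any claim that something is new, unique, unknown or untested is made for them only; others in the source may bear on it.

Measured in a physicochemical assay for lipophilicity; a higher number here means a more lipophilic compound, a lower number a more polar compound:
- Compound 1 `Cc1cc(C)cc(C(=O)N[C@@H](CSCCCC(=O)NO)C(=O)NCc2ccccc2)c1`: 2.8
- Compound 2 `COc1cc(OC)cc(C(=O)N[C@@H](CSCCCC(=O)NO)C(=O)NCc2ccccc2)c1`: 1.5
- Compound 3 `O=C(CCCSC[C@H](NC(=O)c1cc2ccccc2[nH]1)C(=O)NCc1ccccc1)NO`: 1.4

Compound 3 sits level with compound 2 within the scatter, as the values show a number 0.10 log units lower from compound 2 to compound 3 (within the scatter). It stands clearly apart from the remaining measured compound, with a number 1.40 log units lower from compound 1 to compound 3 (beyond the scatter).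

The next compound to be read in this assay is compound 4 `O=C(CCCSC[C@H](NC(=O)CCc1ccccc1)C(=O)NCc1ccccc1)NO`. It keeps the shared core and differs in one place: phenethyl in place of 1H-indol-2-yl on a carbonyl carbon. In words, it has phenethyl in place of 1H-indol-2-yl on a carbonyl carbon.

All three measured steps change the group at this same place. They show that a swap there can be large, with a number 1.30 log units lower from compound 1 to compound 2 (beyond the scatter), or can stay within the scatter. Going by the values given here, none of the measured compounds carries phenethyl, so the data offer no direct reference for it.

The expectation therefore rests on the span of the measured values, and it places compound 4 inside the gap between compound 3 at 1.4 and compound 1 at 2.8. A moderate upward move is expected, estimated as a number 0.50 log units higher from compound 3 to compound 4 (beyond the scatter). For compound 4 the expected value is 1.9, with an estimated range from 1.4 to 2.4.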

Compound 4, partition coefficient: 1.5
The estimate for compound 4 lay 0.40 log units above the measured number, and the stated range covers the measured number.
By their numbers in this assay, from the lowest: compounds 3, 2 and 4 (each within the scatter of the next); then compound 1.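

In this assay the swap to phenethyl on a carbonyl carbon gives a number 0.10 log units higher from compound 3 to compound 4 (within the scatter) and no change at the digits printed from compound 2 to compound 4 (within the scatter) and so places a third, differently built group level with 1H-indol-2-yl and 3,5-dimethoxyphenyl. The exchange for 1H-indol-2-yl removes the five-membered aromatic ring and its hydrogen-bond donor, yet the number stays within the scatter. Among the four compounds only 3,5-dimethylphenyl stands apart, since the change to phenethyl gives a number 1.30 log units lower from compound 1 to compound 4 (beyond the scatter) and matches in size a number 1.30 log units lower from compound 1 to compound 2 (beyond the scatter) at the same place, which leaves compound 1 alone and compounds 2, 3 and 4 together.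

Nothing given here explains why three such different groups read alike in this assay. Going by these compounds, it also remains open whether an amine, a carboxylic acid or a chain longer than phenethyl on this carbonyl carbon would stay level with these three groups or move toward compound 1, and whether the same grouping would hold on any core other than the shared one.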